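The compounds below may be only part of what the source reports. "The series", "measured", "known", "first", "only" and "open" are said of these compounds alone.

Series notes. In an assay on SK-BR-3 cells for inhibition of Aromatase (Homo sapiens) (on this read-out lower numbers stand for stronger inhibition and higher numbers for weaker inhibition), compound 1 `CS(=O)(=O)Nc1ccc([N+](=O)[O-])cc1OCc1ccccc1-c1ccccc1` gives 260 nM. Compound 2 `Cc1ccc(COc2cc([N+](=O)[O-])ccc2NS(C)(=O)=O)cc1` gives 1750 nM in this assay, and compound 3 `CN(c1ccc([N+](=O)[O-])cc1OCc1ccc(Cl)cc1)S(C)(=O)=O` gives 2400 nM. Of the three numbers, compound 2 stands second highest: compound 3 is within the scatter of it, while compound 1 lies beyond the scatter with the lower number. Compound 4 `CS(=O)(=O)Nc1ccc([N+](=O)[O-])cc1OCc1ccc(-c2ccccc2)cc1` is not yet measured. Relative to compound 2 it carries phenyl in place of methyl on an aromatic carbon, phenyl in place of methyl on an aromatic carbon. Among the compounds with values here, no measured pair shows this change; the only guide is compound 1, the one measured compound that also carries a phenyl, with 260 nM. For compound 4 the expected step is a 2.9-fold lower number from compound 2 to compound 4 (0.46 log units; beyond the scatter), a lower number beyond the scatter. The estimate for compound 4 is 600 nM, with a range of 200 nM to 2000 nM.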

Compound 4, half-maximal inhibitory concentration: 850 nM
Beside the measured number, compound 4's estimate is 1.4-fold (0.15 log units) below it, and the stated range covers the measured number.
By their numbers in this assay, from the lowest: compound 1; then compound 4; then compounds 2 and 3 (each within the scatter of the next).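

On an aromatic carbon para to a large group, phenyl in place of methyl now has its first measured pair, with a 2.1-fold lower number from compound 2 to compound 4 (0.31 log units; beyond the scatter), a modest step. At this position, the larger group therefore goes with a lower number rather than a loss of inhibition. No measurement shown here accounts for the step.

Open, as far as these compounds go, is whether an amine, a carboxylic acid or a longer chain at this position would lower the number further or raise it. The effects of the chloro group and the extra methyl in compound 3 also remain unseparated.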